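Methoxy removal on the aryl ring, tested on a second core

The source may hold more compounds than are shown below. What is called first, only, known or untested is meant among the compounds shown, and "the series" means these compounds.

Compound 1 `COc1cc(-c2cc(/C=C/C(=O)c3ccc(N)cc3)[nH]n2)cc(OC)c1OC` gives 2770 nM in a functional assay on RPMI-8226 cells (Homo sapiens) for inhibition, read by sulforhodamine B assay, with a stated time of 48 h; on this read-out higher numbers stand for weaker inhibition of growth and lower numbers for stronger inhibition of growth. Compound 2 `COc1ccc(-c2cc(/C=C/C(=O)c3ccc(N)cc3)[nH]n2)cc1OC` differs from compound 1 by hydrogen in place of methoxy on an aromatic carbon and in this assay compound 2 gives 5520 nM; the step is a 2.0-fold higher number from compound 1 to compound 2 (0.30 log units; within the scatter). Compound 3 `COc1cc(C(=O)/C=C/c2cc(-c3cc(OC)c(OC)c(OC)c3)n[nH]2)cc(OC)c1OC` rests on another core; the difference between the two cores is not broken down here. In this assay compound 3 gives 2060 nM. Compound 4 `COc1ccc(-c2cc(/C=C/C(=O)c3cc(OC)c(OC)c(OC)c3)[nH]n2)cc1OC` has not been measured; it differs from compound 3 by hydrogen in place of methoxy on an aromatic carbon, the same change as between compound 1 and compound 2, at a place described in identical words. On the strength of a 2.0-fold higher number from compound 1 to compound 2 (0.30 log units; within the scatter), the expected step is a 2.0-fold higher number from compound 3 to compound 4 (0.30 log units; within the scatter). Going by the values given here, only one earlier instance of this change is known, so the range is kept wide. Compound 4 is estimated at 4100 nM, between 1800 nM and 9500 nM.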

Compound 4, concentration for total growth inhibition: 1660 nM
Compound 4: middle estimate off by 2.5-fold (0.39 log units), on the high side, outside the stated range (below it).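

In this assay, replacing the methoxy group with hydrogen on the second core gives a 1.2-fold lower number from compound 3 to compound 4 (0.09 log units; within the scatter) and does not reproduce the direction of the earlier step, but the two steps cannot be told apart: the same change on two cores in this assay, a 2.0-fold higher number (0.30 log units; within the scatter) from compound 1 to compound 2 and a 1.2-fold lower number (0.09 log units; within the scatter) from compound 3 to compound 4, 2.5-fold (0.39 log units) apart, within the scatter of two such steps.
Neither step lies beyond the scatter, so this change shows no measurable effect on growth inhibition on either core, and nothing here marks the two cores as responding differently. This does not prove that the cores respond alike, and two pairs say nothing about any further core.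

Still open, on these data alone, is whether a hydroxy group or a fluorine atom in place of this methoxy group would give a step beyond the scatter. Also open, as far as these compounds go, is whether an amine on the aryl ring of compound 3 would do so.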